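A few compounds are considered here, and "the series" means these few. Any claim that something is new, unique, unknown or untested is made for them only; others in the source may bear on it.

Measured compounds:
- compound 1, `O=S(=O)(c1ccc(F)c(F)c1)c1cnc2c(F)cccc2c1-c1ccccc1F`: 1.39 mL/min
- compound 2, `O=S(=O)(c1ccc(F)c(F)c1)c1cnc2c(F)cccc2c1-c1cccc(F)c1`: 1.28 mL/min
- compound 3, `COc1ccc(-c2c(S(=O)(=O)c3ccc(F)c(F)c3)cnc3c(F)cccc23)cc1`: 2.12 mL/min

All three numbers come from an ADME assay on microsomes from liver (Homo sapiens) for metabolic stability, tested at 2.5 uM; a higher number here means faster removal of the compound, a lower number slower removal. Compound 1 stands second highest of the three; its nearest neighbour is compound 2, and the gap is within the scatter, as is the gap to compound 3. Both measured steps from compound 1 change the aryl on the aromatic carbon of the core: a 1.1-fold lower number from compound 1 to compound 2 (0.04 log units; within the scatter) and a 1.5-fold higher number from compound 1 to compound 3 (0.18 log units; within the scatter). The remaining step, a 1.7-fold higher number from compound 2 to compound 3 (0.22 log units; within the scatter), is also within the scatter.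

Compound 4, `N#Cc1cccc(S(=O)(=O)c2cnc3c(F)cccc3c2-c2ccccc2F)c1`, is not yet measured in this assay. Its change from compound 1 is 3-cyanophenyl in place of 3,4-difluorophenyl on a sulfonyl sulfur. For the measured compounds named here, no measured step touches the group on the sulfonyl sulfur, so none of the three steps bears directly on this change. The three measured steps elsewhere in the series all stayed within the scatter. On that basis no step beyond the scatter is expected in this assay for compound 4; the step of a 1.1-fold higher number from compound 1 to compound 4 (0.03 log units; within the scatter) is the estimate. Compound 4 is expected to give about 1.5 mL/min, with a range from 0.75 mL/min to 3 mL/min.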

Compound 4, intrinsic clearance in a liver preparation (reported as CLH), per the amount of preparation that the assay uses: 0.66 mL/min
The estimate for compound 4 lay 2.3-fold (0.36 log units) above the measured number; measured number below the stated range.
By their numbers in this assay, from the lowest: compounds 4, 2, 1 and 3 (each within the scatter of the next, the first and the last beyond it).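

In this assay, for the compounds shown here, the group on the sulfonyl sulfur is the first place where a single change gives a step beyond the scatter: 3-cyanophenyl in place of 3,4-difluorophenyl gives a 2.1-fold lower number from compound 1 to compound 4 (0.32 log units; beyond the scatter). The three steps among aryl groups on the aromatic carbon of the core all stayed within the scatter, so the sulfonyl aryl cannot be treated as equally tolerant of change in this assay. No measurement shown accounts for this modest step, and it remains an observation from one pair.

As far as these compounds go, whether the step follows from the nitrile or from the loss of both fluorines remains open, and an unsubstituted phenyl or a 3-fluorophenyl on the sulfonyl sulfur would separate the two. Also open, from the compounds shown here alone, is whether the same exchange carries over when 3-fluorophenyl or 4-methoxyphenyl occupies the aromatic carbon.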